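Aryl swap on an aromatic nitrogen: outlook for compound 4

The source may hold more compounds than are shown below. What is called first, only, known or untested is meant among the compounds shown, and "the series" means these compounds.

Compound 1 `Cc1ccccc1-n1nncc1CN1C(=O)C2(C(C#N)=C(N)Oc3c2c2nc4ccccc4nc2c2ccccc32)c2ccccc21` and compound 2 `COc1ccc(-n2nncc2CN2C(=O)C3(C(C#N)=C(N)Oc4c3c3nc5ccccc5nc3c3ccccc43)c3ccccc32)cc1` share a core and differ only in the group on an aromatic nitrogen. In a functional assay on A549 cells (Homo sapiens) for antiproliferative activity, read by MTT assay, with a stated time of 48 h (on this read-out lower numbers stand for stronger inhibition and higher numbers for weaker inhibition), compound 1 gives only the limit > 50000 nM. Compound 2 likewise gives only the limit > 50000 nM in this assay. The step that the two limits leave unreadable from compound 1 to compound 2 is therefore not readable, as both values sit at the limit of > 50000 nM in this assay, at which 2 of the 3 values shown sit. Within the data shown here, compound 3 `N#CC1=C(N)Oc2c(N)cc3nc4ccccc4nc3c2C12C(=O)N(Cc1cnnn1-c1cccc(Br)c1)c1ccccc12` carries a different core and a 3-bromophenyl on the aromatic nitrogen; in this assay compound 3 gives 18900 nM, the only number in the set.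

Compound 4 `N#CC1=C(N)Oc2c(N)cc3nc4ccccc4nc3c2C12C(=O)N(Cc1cnnn1-c1cc(Cl)ccc1Cl)c1ccccc12` differs from compound 3 by 2,5-dichlorophenyl in place of 3-bromophenyl on an aromatic nitrogen. Among the measured compounds shown here, no measured step bears on this change: the one step available, between compound 1 and compound 2, is unreadable, and no pair varies the same position with a readable outcome. Compound 4 is therefore expected to sit close to compound 3, with a step of a 1.1-fold higher number from compound 3 to compound 4 (0.02 log units; within the scatter) not beyond the scatter. For compound 4 in this assay the estimate is 20000 nM, expected between 6000 nM and 60000 nM.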

Compound 4, half-maximal inhibitory concentration: 10900 nM
Beside the measured number, compound 4's estimate is 1.8-fold (0.26 log units) above it; the range from low to high includes it.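

Among these compounds, the core of compound 3 gives the first readable step at this position in this assay: a 1.7-fold lower number from compound 3 to compound 4 (0.24 log units; within the scatter). On this core, 2,5-dichlorophenyl and 3-bromophenyl are not told apart by this read-out, even though the entering group carries two chlorine atoms and the leaving group one bromine. The step between compound 1 and compound 2 offers no such reading, as both values are limits of the assay: the limit of > 50000 nM in this assay, at which 2 of the 4 values shown sit.

Going by these compounds, the effect on the core of compound 3 of an aryl group carrying an amine or a carboxylic acid, or of a longer alkyl chain in place of the aryl group, stays open. Also open, on these data alone, is whether any group on this aromatic nitrogen can shift the value beyond the scatter from compound 3.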